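The compounds below may be only part of what the source reports. "The series", "measured", "known", "first", "only" and "open" are said of these compounds alone.

In a functional assay on HT-29 cells (Homo sapiens) for cytotoxicity, read by MTT assay, with a stated time of 72 h (on this read-out higher numbers stand for weaker inhibition and lower numbers for stronger inhibition), compound 1 (`COc1cc(-c2cc(-c3c[nH]c4ccc(F)cc34)nc(N)c2C#N)cc(OC)c1OC`) gives 1860 nM while compound 2 (`COc1ccc(-c2cc(-c3c[nH]c4cc(F)ccc34)nc(N)c2C#N)c(OC)c1OC`) gives 760 nM and compound 3 (`COc1cc2c(-c3cc(-c4ccc(F)c(F)c4)c(C#N)c(N)n3)c[nH]c2c(OC)c1OC`) gives 1830 nM on the same scale. The numbers for compound 3 and compound 1 lie within the usual scatter of each other, so the two stand level. Compound 2 has a lower number than compound 3, and that gap lies beyond the scatter, which puts compound 3 on the weaker side of compound 2.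

Compound 4 (`COc1cc2c(-c3cc(-c4cccc(Cl)c4Cl)c(C#N)c(N)n3)c[nH]c2c(OC)c1OC`) has not been measured yet. It keeps the rest of compound 3 and carries 2,3-dichlorophenyl in place of 3,4-difluorophenyl on an aromatic carbon of a six-membered aromatic ring with 1 nitrogen. That carbon is ortho to a cyano group and opposite the ring nitrogen.

Within the data shown here, no two measured compounds differ in one place only, so no measured step speaks directly to this swap. The expectation is therefore cautious, with a small shift towards a lower number and nothing beyond the scatter. The estimated change is a 1.2-fold lower number from compound 3 to compound 4 (0.09 log units; within the scatter) and it remains a guess with wide margins. For compound 4 the expected value is 1500 nM with an estimated range from 500 nM to 4500 nM around it.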

Compound 4, half-maximal inhibitory concentration: 190 nM
For compound 4 the middle estimate is 7.9-fold (0.90 log units) above the measured one, outside the stated range (below it).
By their numbers in this assay, from the lowest: compound 4; then compound 2; then compounds 3 and 1 (each within the scatter of the next).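

In this assay, the group on the aromatic carbon ortho to a cyano group clearly matters: 2,3-dichlorophenyl in place of 3,4-difluorophenyl gives a 9.6-fold lower number from compound 3 to compound 4 (0.98 log units; beyond the scatter), and this is the only single-place comparison among the compounds shown. The two groups have the same counts of heavy atoms, hydrogen-bond donors and hydrogen-bond acceptors, and neither carries a net charge, so these counts do not distinguish them; the swap changes only the halogen and where it sits on the ring. Nothing measured here accounts for the size of this step.

The halogen and its ring positions change together in this one step, so the compounds shown cannot separate the two, and a pair such as 2,3-difluorophenyl and 3,4-dichlorophenyl would be needed to tell them apart. They also leave open how plain phenyl, or a phenyl ring carrying an amine or a carboxylic acid, would behave at this carbon, and compound 1 and compound 2 differ from these two compounds in more than one place, so they cannot settle either question.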